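Dropping the Nitrile from Compound 2

The source may hold more compounds than are shown below. What is called first, only, known or untested is meant among the compounds shown, and "the series" means these compounds.

Among the measured compounds shown here, compound 2 `CCN(CCC#N)c1nc(C)nc2c(-c3c(C)cc(OC)cc3OC)c(C)nn12` is one of two compounds measured in an assay on cell membranes for displacement of a labelled ligand from corticotropin-releasing factor receptor 1 (Rattus norvegicus) (on this read-out higher numbers stand for weaker inhibition and lower numbers for stronger inhibition), and gives the higher of the two numbers, at 2.48 nM. Compound 1 `CCC(CC)Nc1nc(C)nc2c(-c3cc(F)c(OC)cc3Cl)c(C)nn12` gives 1 nM in this assay, a gap from compound 2 that lies beyond the usual scatter. Compound 3 `CCN(CC)c1nc(C)nc2c(-c3c(C)cc(OC)cc3OC)c(C)nn12` is not yet measured; it differs from compound 2 by hydrogen in place of cyano on a saturated chain carbon, two bonds along the chain from a nitrogen on an aromatic ring. For the measured compounds named here, with no matching step among the measured compounds, the expected step from compound 2 to compound 3 in this assay is a 1.4-fold higher number from compound 2 to compound 3 (0.15 log units; within the scatter), which is within the scatter or only slightly weaker. Compound 3 is therefore expected to give about 3.5 nM in this assay, with a range from 1.2 nM to 10 nM.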

Compound 3, half-maximal inhibitory concentration: 1.2 nM
For compound 3 the middle estimate is 2.9-fold (0.46 log units) above the measured one; the measured number falls inside the stated range.
By their numbers in this assay, from the lowest: compounds 1 and 3 (each within the scatter of the next); then compound 2.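

In this assay the cyano group on this saturated chain carbon proves dispensable: replacing it with hydrogen turns 2-cyanoethyl into ethyl and gives a 2.1-fold lower number from compound 2 to compound 3 (0.32 log units; beyond the scatter) as a modest gain. Among the compounds shown here, this is the first step read at this position, and it shows that the hydrogen-bond acceptor counted with the cyano group can leave without loss on this read-out. Nothing available explains the gain.

On these data alone, whether a hydroxyl, an amine or a longer chain here would track hydrogen or cyano remains open. So does whether this step carries over to other aryl groups on the shared core.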